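Replacing the piperazine with an open-chain diethylamine

The source may hold more compounds than are shown below. What is called first, only, known or untested is meant among the compounds shown, and "the series" means these compounds.

Three compounds that share a core were measured in a functional assay on cells (Homo sapiens) for antiproliferative activity, read by MTT assay, with a stated time of 48 h; a higher number here means a weaker inhibitor, a lower number a stronger inhibitor. Compound 1 `CN(C)CCn1c(N)c(-c2nc3ccccc3[nH]2)c2nc(C#N)c(C#N)nc21` gives 43500 nM. Compound 2 `CN1CCN(CCn2c(N)c(-c3nc4ccccc4[nH]3)c3nc(C#N)c(C#N)nc32)CC1` gives 9110 nM, and compound 3 `CN1CCN(CCCn2c(N)c(-c3nc4ccccc4[nH]3)c3nc(C#N)c(C#N)nc32)CC1` gives 4520 nM. Compound 2 therefore stands second highest of the three numbers: the change a 4.8-fold lower number from compound 1 to compound 2 (0.68 log units; beyond the scatter) is beyond the scatter, while the change a 2.0-fold lower number from compound 2 to compound 3 (0.30 log units; within the scatter) is within it.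

The unmeasured compound 4 `CCN(CC)CCCCn1c(N)c(-c2nc3ccccc3[nH]2)c2nc(C#N)c(C#N)nc21` differs from compound 2 by one change: 2-(diethylamino)ethyl in place of 4-methylpiperazin-1-yl on a saturated chain carbon, two bonds along the chain from an aromatic nitrogen. Going by the values given here, no measured step covers exactly this change. What bears on it is that a dimethylamino at the same place gave the highest number, compound 1, and that the change a 9.6-fold lower number from compound 1 to compound 3 (0.98 log units; beyond the scatter) came with a ring amine placed further out. Compound 4 returns to an open-chain amine, which argues for a higher number than compound 2, but the longer chain of compound 4 argues the other way. The expected outcome for compound 4 is therefore a modest rise, a 1.6-fold higher number from compound 2 to compound 4 (0.22 log units; within the scatter). Compound 4 is estimated at 15000 nM, with a range from 5000 nM to 45000 nM.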

Compound 4, half-maximal inhibitory concentration: 640 nM
For compound 4 the middle estimate is 23-fold (1.37 log units) above the measured one; the whole stated range lies above it.
By their numbers in this assay, from the lowest: compound 4; then compounds 3 and 2 (each within the scatter of the next); then compound 1.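

In this assay the open-chain 4-(diethylamino)butyl group gives the lowest number of the four compounds, with a 14-fold lower number from compound 2 to compound 4 (1.15 log units; beyond the scatter) and a 7.1-fold lower number from compound 3 to compound 4 (0.85 log units; beyond the scatter), so at this position a ring amine is not required for the lowest number in the set. The step from the short open-chain compound is larger still, with a 68-fold lower number from compound 1 to compound 4 (1.83 log units; beyond the scatter), so an open-chain amine does not by itself go with a high number. Nothing available explains the size of this change.

The compounds shown leave open whether the gain goes with the diethylamino group or with the longer chain, as the two change together here. A 4-(4-methylpiperazin-1-yl)butyl group, a 4-(dimethylamino)butyl group or a still longer chain carrying diethylamino could separate the two.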